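A few compounds are considered here, and "the series" means these few. Any claim that something is new, unique, unknown or untested is made for them only; others in the source may bear on it.

Working notes on the series. Compound 1 `Cc1ccc(-c2cn(C/C=C3\OC(=O)C(OCc4ccccc4)=C3OCc3ccccc3)nn2)cc1` carries a 4-methylphenyl on the shared core. In a functional assay on MCF7 cells (Homo sapiens) for antiproliferative activity, read by MTT assay, with a stated time of 72 h (a higher number here means a weaker inhibitor, a lower number a stronger inhibitor), compound 1 gives > 100000 nM, which is a limit of the assay and not a number. Compound 3 `O=C1O/C(=C\Cn2cc(-c3cc(C(F)(F)F)cc(C(F)(F)F)c3)nn2)C(OCc2ccccc2)=C1OCc1ccccc1` likewise returns only a limit in this assay, > 100000 nM. For the measured compounds named here, compound 2 `O=C1O[C@H]([C@@H](O)Cn2cc(-c3cccc(O)c3)nn2)C(OCc2ccccc2)=C1OCc1ccccc1` is the one member with a measured number: in this assay compound 2 gives 51800 nM. Going by the values given here, compound 1 therefore sits at the limit together with compound 3 (the limit of > 100000 nM in this assay, at which 2 of the 3 values shown sit), and no pair of measured compounds differs in a single place, so no measured step is available for this assay.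

Compound 4 `COc1ccc(-c2cn(C/C=C3\OC(=O)C(OCc4ccccc4)=C3OCc3ccccc3)nn2)cc1` differs from compound 1 by methoxy in place of methyl on an aromatic carbon. Nothing measured within the series speaks to the size of such a change. The expected step from compound 1 to compound 4 is none beyond the scatter, a number no higher from compound 1 to compound 4 (the limit leaves the size open), with compound 4 expected to remain at or near the limit of this assay. The estimate for compound 4 in this assay is 100000 nM, expected between 40000 nM and 250000 nM.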

Compound 4, half-maximal inhibitory concentration: 39100 nM
Beside the measured number, compound 4's estimate is 2.6-fold (0.41 log units) above it; measured number outside the range, below it.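

In this assay, for the compounds shown here, the change from 4-methylphenyl to 4-methoxyphenyl gives the first readable single-place step, an at least 2.5-fold lower number from compound 1 to compound 4 (0.40 log units; beyond the scatter), so this position, on an aromatic carbon para to a large group, does respond to substitution. With this one change on the shared core, compound 4 gives a measured number, 39100 nM. The full size of the step stays open because compound 1 stands only at a limit of the assay, not at a number: the limit of > 100000 nM in this assay, at which 2 of the 4 values shown sit.

One step cannot separate the oxygen from the extra heavy atom, and an ethoxy group, an amine or a carboxylic acid at the same place would test that. As far as these compounds go, whether the change carries over to the core of compound 2 also remains open.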